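This account rests on a few compounds, and the source may have more. Where it says the series, first, only, none or still open, it means among the compounds named here.

Compound 1 `Clc1ccc(-c2cc(-c3ccco3)cc(-c3ccc(Cl)s3)n2)cc1`: 1520 nM
Compound 2 `Clc1cccc(-c2cc(-c3ccoc3)cc(-c3ccc(Cl)s3)n2)c1`: 2920 nM

In a functional assay on MCF7 cells (Homo sapiens) for cytotoxicity, read by ELISA, with a stated time of 4 days (on this read-out higher numbers stand for weaker inhibition and lower numbers for stronger inhibition), compound 2 gives 2920 nM and compound 1 gives 1520 nM. Going by the values given here, these two values lie within the scatter of each other, so compound 2 stands level with the only other number available. Compound 3 `Clc1ccc(-c2cc(-c3ccoc3)cc(-c3ccc(Cl)s3)n2)cc1` has the same atoms as compound 2, joined differently: 4-chlorophenyl in place of 3-chlorophenyl on an aromatic carbon. Among the compounds with values here, no pair of measured compounds differs in one place, so the data hold no direct precedent for this change. In this assay, no step beyond the scatter is expected, and no direction can be argued with confidence. The expected 1.3-fold lower number from compound 2 to compound 3 (0.12 log units; within the scatter) is therefore small and remains within the scatter. For compound 3 the estimated value is 2200 nM, with an expected range of 900 nM to 5500 nM.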

Compound 3, half-maximal inhibitory concentration: 2600 nM
Compound 3: the middle estimate sits 1.2-fold (0.07 log units) below what was measured, within the range that was stated.
By their numbers in this assay, from the lowest: compounds 1, 3 and 2 (each within the scatter of the next).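

In this assay, going by these compounds alone, 4-chlorophenyl in place of 3-chlorophenyl on the aromatic carbon next to the ring nitrogen gives a 1.1-fold lower number from compound 2 to compound 3 (0.05 log units; within the scatter), so the first direct comparison at this position does not separate the two chlorine placements. With 4-chlorophenyl held fixed, furan-3-yl in place of furan-2-yl gives a 1.7-fold higher number from compound 1 to compound 3 (0.23 log units; within the scatter), so the two furan attachments are not separated either. No measured evidence bears on the reason for either result.

All three compounds keep a chlorophenyl group, a furan and the 5-chlorothiophen-2-yl group, so these steps cover only changes in how the same atoms are joined. From the compounds shown here alone, whether a different group at the position next to the ring nitrogen, such as an amine or a carboxylic acid on the phenyl ring in place of chlorine, would give a step beyond the scatter remains open.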